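From Bromo to Aromatic Rings, and Now Furan-2-yl

The source may report more compounds than this note shows. Statements on the series, on what has been measured and on what is new or still open speak of the compounds shown alone.

Of the compounds shown here, three sharing one core have been measured in a functional assay on HOS cells (Homo sapiens) for inhibition, with a stated time of 72 h; on this read-out higher numbers stand for weaker inhibition and lower numbers for stronger inhibition. Compound 1 `NC1CCC(Nc2nc(NCc3ccc(Br)cc3)c3ncn(C4CCCC4)c3n2)CC1`, which carries bromo, gives 995 nM. Compound 2 `NC1CCC(Nc2nc(NCc3ccc(-c4ccccc4)cc3)c3ncn(C4CCCC4)c3n2)CC1`, with phenyl in its place, gives 290 nM. Compound 3 `NC1CCC(Nc2nc(NCc3ccc(-c4cccc(F)c4)cc3)c3ncn(C4CCCC4)c3n2)CC1`, with 3-fluorophenyl there, gives 211 nM. This puts compound 3 well clear of compound 1 but level with compound 2, as the record shows a 1.4-fold lower number from compound 2 to compound 3 (0.14 log units; within the scatter).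

Compound 4 `NC1CCC(Nc2nc(NCc3ccc(-c4ccco4)cc3)c3ncn(C4CCCC4)c3n2)CC1` changes this group once more, with furan-2-yl in place of 3-fluorophenyl on an aromatic carbon. The change sits on a six-membered aromatic ring of carbon only, para to a large group.

Among the compounds with values here, two measured steps bear on it, and both are modest: a 3.4-fold lower number from compound 1 to compound 2 (0.54 log units; beyond the scatter) and a 4.7-fold lower number from compound 1 to compound 3 (0.67 log units; beyond the scatter). Each replaces bromo with an aromatic ring. Adding fluoro to the phenyl made no difference beyond the scatter. No five-membered aromatic ring has been measured at this place, so the data do not test the new group directly. Compound 4 still has an aromatic ring there, so it is expected to stay close to compound 2 and compound 3 in this assay, with no step beyond the scatter. The expected change is a 1.4-fold higher number from compound 3 to compound 4 (0.15 log units; within the scatter). For compound 4 the estimated value is 300 nM, with an expected range of 120 nM to 750 nM.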

Compound 4, half-maximal inhibitory concentration: 102 nM
Compound 4: the middle estimate sits 2.9-fold (0.47 log units) above what was measured; measured number outside the range, below it.
By their numbers in this assay, from the lowest: compound 4; then compounds 3 and 2 (each within the scatter of the next); then compound 1.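

In this assay, within the data shown here, the earlier compounds showed only that an aromatic ring in place of bromo lowers the number, while adding fluoro to the phenyl stayed within the scatter; the furan-2-yl now shows that the kind of aromatic ring at this place also counts, with a 2.1-fold lower number from compound 3 to compound 4 (0.32 log units; beyond the scatter) and a 2.8-fold lower number from compound 2 to compound 4 (0.45 log units; beyond the scatter), both beyond the scatter. This five-membered aromatic ring with 1 hetero atom, carrying fewer heavy atoms than either six-membered ring, goes further than both, and with a 9.8-fold lower number from compound 1 to compound 4 (0.99 log units; beyond the scatter) the full change from bromo makes compound 4 the strongest inhibitor of the four. Nothing available explains why the furan-2-yl outperforms the other rings, so the gain cannot be assigned to its oxygen, its size or anything else.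

The compounds shown leave open whether the ring oxygen is what counts, a question that a thiophen-2-yl or a furan-3-yl would put directly, and how a pyridine ring or a phenyl bearing an amine would fare at this place. They also leave open whether the same order would hold on the shared core with other changes elsewhere.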